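From cyclopropyl to methyl on the aromatic nitrogen

This account rests on a few compounds, and the source may have more. Where it says the series, first, only, none or still open, it means among the compounds named here.

Compound 1 `O=C(O)c1cc(-c2cccc(COc3ccc4c(=O)n(C5CCC5)sc4c3)c2)ccc1Cl` and compound 2 `O=C(O)c1cc(-c2cccc(COc3ccc4c(=O)n(C5CC5)sc4c3)c2)ccc1Cl` share a core that differs only in the group on the aromatic nitrogen. In an assay on HEK293 cells for positive allosteric modulation of metabotropic glutamate receptor 2 (Rattus norvegicus), read by thallium flux (on this read-out higher numbers stand for larger maximal responses and lower numbers for smaller maximal responses), compound 1 gives 83%, and compound 2 gives 70.6%. Among the compounds with values here, the single measured step, a number 12.4 percentage points lower from compound 1 to compound 2 (beyond the scatter), shows that trading cyclobutyl for cyclopropyl lowers the maximal response. Compound 3 `O=C1c2ccc(OCc3cccc(-c4ccc(C(F)(F)F)cc4F)c3)cc2CN1C1CCCC1` carries a different substitution pattern and a different core, and in this assay compound 3 gives "not determined" (no result reported), so it adds nothing to the comparison. Among the two numbers available, compound 2 stands lowest, with compound 1 as its only neighbour.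

Compound 4 `Cn1sc2cc(OCc3cccc(-c4ccc(Cl)c(C(=O)O)c4)c3)ccc2c1=O` continues in the same direction: methyl in place of cyclopropyl on an aromatic nitrogen. Within the data shown here, the one relevant precedent is the step from compound 1 to compound 2, where a smaller ring on the nitrogen gave a modest decrease. If the trend of shrinking the group on that nitrogen holds, a further, similarly modest decrease is expected, though the methyl group is a different kind of change than one ring for another, so the expectation is uncertain. Compound 4 is therefore expected to reach 62%, within 45% to 78%, corresponding to an expected step of a number 8.6 percentage points lower from compound 2 to compound 4 (within the scatter).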

Compound 4, largest response reached (reported as percent of maximum), in percent of the reference or control that the assay uses: 74.7%
For compound 4 the middle estimate is 12.7 percentage points below the measured one; the range from low to high includes it.
By their numbers in this assay, from the lowest: compounds 2, 4 and 1 (each within the scatter of the next, the first and the last beyond it).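

In this assay, methyl in place of cyclopropyl on an aromatic nitrogen gives a number 4.1 percentage points higher from compound 2 to compound 4 (within the scatter), and methyl in place of cyclobutyl gives a number 8.3 percentage points lower from compound 1 to compound 4 (within the scatter), so the methyl group cannot be told apart from either ring at this position. The earlier pair, with a number 12.4 percentage points lower from compound 1 to compound 2 (beyond the scatter), could be read as the maximal response falling as the group on this nitrogen shrinks, but compound 4, which carries the smallest of the three groups, goes against that reading, and only compound 1 and compound 2 remain separated beyond the scatter. Nothing at hand explains why the response at this position does not follow the size of the group.

The compounds shown leave open whether an ethyl group, a longer chain such as n-propyl, or a chain ending in an amine on this nitrogen would stay within the same narrow band of maximal response on the shared core. They also leave open whether methyl, cyclopropyl and cyclobutyl on this nitrogen would compare in the same way on a different core.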